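This account rests on a few compounds, and the source may have more. Where it says the series, first, only, none or still open, it means among the compounds named here.

In an ADME assay on microsomes from liver (Mus musculus) for metabolic stability, with a stated time of 10 min (a lower number here means that less of the compound is left, a higher number that more of the compound is left), compound 1 `O=C(O)[C@H]1CC[C@H](C(=O)N2CC[C@](c3ccc(C(OCc4ccccc4OC(F)(F)F)(C(F)(F)F)C(F)(F)F)cc3)(S(=O)(=O)c3ccc(F)cc3)C2)CC1` stands at 81% and compound 2 `Cc1cccc(C)c1COC(c1ccc([C@]2(S(=O)(=O)c3ccc(F)cc3)CCN(C(=O)[C@H]3CC[C@H](C(=O)O)CC3)C2)cc1)(C(F)(F)F)C(F)(F)F` at 77% while compound 3 `O=C(O)[C@H]1CC[C@H](C(=O)N2CC[C@](c3ccc(C(OCc4c(F)cccc4Cl)(C(F)(F)F)C(F)(F)F)cc3)(S(=O)(=O)c3ccc(F)cc3)C2)CC1` stands at 87% and so lies within the scatter of the other two. Compound 4 `O=C(O)[C@H]1CC[C@H](C(=O)N2CC[C@](c3ccc(C(OCC4CC4)(C(F)(F)F)C(F)(F)F)cc3)(S(=O)(=O)c3ccc(F)cc3)C2)CC1` puts cyclopropyl in place of 2-chloro-6-fluorophenyl on a saturated chain carbon bound to an oxygen on a saturated carbon, a change counted as cyclopropyl in place of 2-chloro-6-fluorophenyl on a saturated chain carbon bound to an oxygen on a saturated carbon and not yet measured. The nearest evidence comes from exchanges of one phenyl group for another at that place: a number 4 percentage points lower from compound 1 to compound 2 (within the scatter) and a number 6 percentage points higher from compound 1 to compound 3 (within the scatter) and a number 10 percentage points higher from compound 2 to compound 3 (within the scatter) all stayed within the scatter. Within the data shown here, no measured step replaces the aromatic ring with a non-aromatic one, so this guide is only indirect. The expected step is a number 7 percentage points lower from compound 3 to compound 4 (within the scatter) and no shift beyond the scatter is expected. For compound 4 the estimated value is 80% (expected range 62% to 93%)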

Compound 4, percent of the compound remaining: 44%
Beside the measured number, compound 4's estimate is 36 percentage points above it; measured number outside the range, below it.
By their numbers in this assay, from the lowest: compound 4; then compounds 2, 1 and 3 (each within the scatter of the next).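

Exchanging one substituted phenyl group for another at this place stayed within the scatter, but cyclopropyl moves the result beyond it in this assay against all three phenyl compounds: a number 43 percentage points lower from compound 3 to compound 4 (beyond the scatter) and a number 33 percentage points lower from compound 2 to compound 4 (beyond the scatter) and a number 37 percentage points lower from compound 1 to compound 4 (beyond the scatter). The position is therefore not indifferent to its group, and here an aromatic ring of carbon gives way to a three-membered non-aromatic ring with much less compound left. Nothing available explains this drop. Still open, going by these compounds, is whether a cyclohexyl group, an unsubstituted phenyl or a straight butyl chain at this place would match compound 4 or the phenyl compounds.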